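Swapping an Ester-Bearing Amide for an Amino Acid Amide

The source may report more compounds than this note shows. Statements on the series, on what has been measured and on what is new or still open speak of the compounds shown alone.

Of the compounds shown here, three sharing one core have been measured in a functional assay on Caco-2 cells (Homo sapiens), read by MTT assay, with a stated time of 48 h; a higher number here means a weaker inhibitor, a lower number a stronger inhibitor. Compound 1 `CCOC(=O)CN(C)C(=O)c1ccc(C(CC)(CC)c2ccc(OCC(O)C(C)(C)C)c(C)c2)n1CC` gives 12200 nM in this assay, the second highest of the three numbers, standing a bit under compound 2 and above compound 3. Compound 2 `C#CCNC(=O)c1ccc(C(CC)(CC)c2ccc(OCC(O)C(C)(C)C)c(C)c2)n1CC` gives 39100 nM, and compound 3 `CC[C@@H](C)[C@H](NC(=O)c1ccc(C(CC)(CC)c2ccc(OCC(=O)C(C)(C)C)c(C)c2)n1CC)C(=O)O` gives 4500 nM.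

The step to compound 4 `CC[C@@H](C)[C@H](NC(=O)c1ccc(C(CC)(CC)c2ccc(OCC(O)C(C)(C)C)c(C)c2)n1CC)C(=O)O` changes the group on the carbonyl carbon: (1-carboxy-2-methylbutyl)amino in place of ((ethoxycarbonyl)methyl)(methyl)amino on a carbonyl carbon. Among the compounds with values here, the only measured step at that position, a 3.2-fold higher number from compound 1 to compound 2 (0.51 log units; beyond the scatter), went the other way, toward a weaker inhibitor. Within the data shown here, compound 3, which carries the same (1-carboxy-2-methylbutyl)amino group on its carbonyl carbon but differs elsewhere, is the only compound with a lower number than compound 1, and the value of compound 3, 4500 nM, is the best guide. Because compound 3 reaches 4500 nM, compound 4 is expected to land near it, with a step of a 2.7-fold lower number from compound 1 to compound 4 (0.43 log units; beyond the scatter).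

Compound 4 is therefore estimated at 4500 nM, within a range from 1500 nM to 14000 nM.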

Compound 4, half-maximal inhibitory concentration: 3400 nM
For compound 4 the middle estimate is 1.3-fold (0.12 log units) above the measured one, and the stated range covers the measured number.
By their numbers in this assay, from the lowest: compounds 4 and 3 (each within the scatter of the next); then compound 1; then compound 2.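

Placing (1-carboxy-2-methylbutyl)amino on the carbonyl carbon gives a direct reading against the ester-bearing group of compound 1 (a 3.6-fold lower number from compound 1 to compound 4 (0.55 log units; beyond the scatter)), and the gap to the propargyl amide is wider still (a 12-fold lower number from compound 2 to compound 4 (1.06 log units; beyond the scatter)), so changes at this one position can move the number in either direction. With this amino acid amide in place, 1-hydroxy-2,2-dimethylpropyl and (tert-butyl)carbonyl cannot be told apart (a 1.3-fold lower number from compound 3 to compound 4 (0.12 log units; within the scatter)). No measured evidence accounts for any of these steps.

Going by these compounds, whether the lower number follows the carboxylic acid or the branched chain stays open. An ethyl ester of the same amino acid group, or a carboxymethylamino group with a shorter chain, would help separate the two.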